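The source may hold more compounds than are shown below. What is called first, only, known or untested is meant among the compounds shown, and "the series" means these compounds.

Measured compounds:
Compound 1, `CC/C(=N\Nc1nc2ccccc2o1)c1ccccn1`: 4 nM
Compound 2, `C/C(=N\Nc1nc2ccccc2o1)c1ccc(C)nn1`: 2550 nM
Compound 3, `C/C(=N\Nc1nc2ccccc2o1)c1nccnc1C`: 1300 nM

Three hydrazones sharing one core were tested in a functional assay on CCRF-CEM cells (Homo sapiens) for antiproliferative activity, read by MTT assay; on this read-out lower numbers stand for stronger inhibition and higher numbers for weaker inhibition. Compound 1 gives 4 nM, by far the lowest number of the set. Compound 2 stands at the top of the three numbers with 2550 nM; compound 3, at 1300 nM, is within the scatter of it, while compound 1 lies far beyond the scatter from both.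

Compound 4, `C/C(=N\Nc1nc2ccccc2o1)c1cccnn1`, has not yet been measured in this assay. It differs from compound 2 in a single place: hydrogen in place of methyl on an aromatic carbon. The methyl sits on the six-membered aromatic ring with 2 nitrogen, next to the ring nitrogen, and is replaced by hydrogen.

No pair of measured compounds differs in only this way, so the effect of the change is not shown by the data. The difference is a single carbon, and compound 2 already stands at the high end of the set. A small step toward a lower number is expected in this assay, quite possibly within the scatter; compound 4 is therefore estimated at 1200 nM, with a range from 250 nM to 6000 nM, and the expected step is a 2.1-fold lower number from compound 2 to compound 4 (0.33 log units; beyond the scatter).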

Compound 4, half-maximal inhibitory concentration: 720 nM
Compound 4: the middle estimate sits 1.7-fold (0.22 log units) above what was measured; low and high end bracket the measured number.
By their numbers in this assay, from the lowest: compound 1; then compounds 4, 3 and 2 (each within the scatter of the next, the first and the last beyond it).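

In this assay the change from methyl to hydrogen on this aromatic carbon, para to a large group, brings a 3.5-fold lower number from compound 2 to compound 4 (0.55 log units; beyond the scatter) and gives the set its first comparison that differs in one place only. The step is modest but beyond the scatter, so the methyl at this place is not needed for the activity seen here, and losing it lowers the number rather than raising it. Nothing in the data shown accounts for the step. From the compounds shown here alone, only methyl and hydrogen appear on this carbon, so it stays open how a chlorine, a methoxy group, an amine or a carboxylic acid would fare there. Within the data shown here, no second pair shows this change, and whether the same replacement would give a similar step elsewhere remains unknown.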